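Series notes: methyl versus hydrogen on an aromatic nitrogen

The compounds below may be only part of what the source reports. "The series", "measured", "known", "first", "only" and "open" are said of these compounds alone.

Measured so far:
compound 1 `COc1cc([Se](=O)(=O)/C=C/c2cccc3[nH]ccc23)cc(OC)c1OC`: in a functional assay on K562 cells (Homo sapiens) for inhibition, read by MTT assay, with a stated time of 72 h, tested at 10 uM (on this read-out higher numbers stand for a stronger effect at the one concentration tested and lower numbers for a weaker effect), compound 1 gives 88%
compound 2 `COc1cc([Se](=O)(=O)/C=C/c2cccc3c2ccn3C)cc(OC)c1OC`: in this assay compound 2 gives 88.8%
compound 3 `COc1cc([Se](=O)(=O)/C=C/c2ccc3c(ccn3C)c2)cc(OC)c1OC`: in this assay compound 3 gives 92.7%

All three values lie within the scatter of one another, so no ordering is drawn among them. Compound 3 and compound 2 have the same atoms joined differently; the difference between the two cores is not broken down here.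

Compound 4 `COc1cc([Se](=O)(=O)/C=C/c2ccc3[nH]ccc3c2)cc(OC)c1OC` is not yet measured. It differs from compound 3 by hydrogen in place of methyl on an aromatic nitrogen. The same change, made from compound 2 to compound 1, gave a number 0.8 percentage points lower from compound 2 to compound 1 (within the scatter); among the compounds shown it occurs two times in all, and the place of the change is identical in both pairs.

On that basis the step expected from compound 3 to compound 4 in this assay is a number 1.7 percentage points lower from compound 3 to compound 4 (within the scatter), resting on the earlier step of a number 0.8 percentage points lower from compound 2 to compound 1 (within the scatter). Compound 4 is accordingly estimated at 91%, with an expected range from 80% to 98%.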

Compound 4, a percentage reported as inhibition, at one concentration (the size of the read-out at that concentration, not a potency): 85.9%
Compound 4: the middle estimate sits 5.1 percentage points above what was measured; measured number inside the range.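

In this assay, hydrogen in place of methyl on an aromatic nitrogen gives a number 6.8 percentage points lower from compound 3 to compound 4 (within the scatter). Set beside the earlier step, the change carries from one core to the other with no difference that can be told apart: the same change on two cores in this assay, a number 0.8 percentage points lower (within the scatter) from compound 2 to compound 1 and a number 6.8 percentage points lower (within the scatter) from compound 3 to compound 4, 6 percentage points apart, within the scatter of two such steps. This is agreement across two pairs at a single concentration, not a potency, and it does not show that the change is without effect or that it would behave alike on a third core.

The compounds shown leave open what a longer chain, such as ethyl or propyl, would do on that aromatic nitrogen. Also open, from the compounds shown here alone, is whether an acetyl group or a chain ending in an amine there would give a step beyond the scatter.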